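Swapping an Amide for a Thioester at Low Inhibition

The source may hold more compounds than are shown below. What is called first, only, known or untested is meant among the compounds shown, and "the series" means these compounds.

Of the compounds shown here, three have been tested in an assay on membranes from CHO cells for displacement of a labelled ligand from adenosine receptor A1 (Homo sapiens), read by scintillation counting, with a stated time of 60 min, tested at 1 uM; a lower number here means less inhibition, a higher number more inhibition at the concentration tested (going by the name of the read-out). Compound 1 `CCCC(=O)C1=C(C)NC(=O)NC1c1ccoc1` gives 1%. Compound 2 `CC1=C(C(N)=O)C(c2ccoc2)NC(=O)N1` gives 1%, and compound 3 `CC1=C(C(N)=O)C(c2ccsc2)NC(=O)N1` gives 2%. The step of no change at the digits printed from compound 1 to compound 2 (within the scatter) and the step of a number 1 percentage points higher from compound 2 to compound 3 (within the scatter) both stay within the scatter, so all three sit together at the bottom of the scale, and compound 2 stands level with compound 1 at the digits shown.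

Compound 4 `CC1=C(C(=O)SC(C)C)C(c2ccoc2)NC(=O)N1` has not been measured yet. It differs from compound 2 in one place: isopropylsulfanyl in place of amino on a carbonyl carbon. Of the measured steps, only no change at the digits printed from compound 1 to compound 2 (within the scatter) touches the same carbonyl carbon, and it was within the scatter. Going by the values given here, no measured step brings in an isopropylsulfanyl group anywhere; the step of a number 1 percentage points higher from compound 2 to compound 3 (within the scatter) changes the ring instead and was also within the scatter. Because no change at the digits printed from compound 1 to compound 2 (within the scatter) showed no change, compound 4 is expected to stay where compound 2 stands, with a number 1 percentage points higher from compound 2 to compound 4 (within the scatter). The estimate for compound 4 is 2%, ranging from 0% to 12%.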

Compound 4, a percentage reported as inhibition, at one concentration (the size of the read-out at that concentration, not a potency): 9%
Estimate against measurement, compound 4: 7 percentage points below; low and high end bracket the measured number.
By their numbers in this assay, from the lowest: compounds 1, 2, 3 and 4 (each within the scatter of the next).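

On the carbonyl carbon whose other neighbour is the double-bonded ring carbon, this assay now covers three groups: propyl, amino and isopropylsulfanyl. Putting isopropylsulfanyl in place of amino gives a number 8 percentage points higher from compound 2 to compound 4 (within the scatter), and putting it in place of propyl gives a number 8 percentage points higher from compound 1 to compound 4 (within the scatter), so a group of this size that carries sulfur still leaves the read-out within the usual scatter at this position. Nothing measured on these compounds bears on this result.

The compounds shown leave open whether a longer chain on the sulfur, or a hydroxyl group or a methoxy group on the same carbonyl carbon, would move the number beyond the scatter. They also leave open whether isopropylsulfanyl gives a similar reading with thiophen-3-yl in place of furan-3-yl.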